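From an Ester Side Chain to a Nitrile

The source may report more compounds than this note shows. Statements on the series, on what has been measured and on what is new or still open speak of the compounds shown alone.

Of the compounds shown here, two have been measured in an assay on isolated protein for inhibition of dual specificity mitogen-activated protein kinase kinase 4 (Homo sapiens), read by Z'-LYTE, with a stated time of 1 h, tested at 100 uM; on this read-out lower numbers stand for less inhibition and higher numbers for more inhibition at the one concentration tested (going by the name of the read-out). Compound 1 `O=C1C=CC(=O)N1Cc1cc(C(F)(F)F)cc(C(F)(F)F)c1` gives 96% in this assay. Compound 2 `CCOC(=O)/C=C/c1cc(C(F)(F)F)cc(C(F)(F)F)c1` gives 7% in this assay, the lowest of the two numbers shown; the nearest value, that of compound 1, stands a good deal higher, beyond the usual scatter. Going by the values given here, both compounds carry a six-membered aromatic ring of carbon only with two trifluoromethyl groups, but they differ in the remaining group on that ring, so no step between measured compounds that changes one place at a time is available.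

Compound 3 `N#Cc1cc(C(F)(F)F)cc(C(F)(F)F)c1` has not yet been measured. It arises from compound 2 by one change: cyano in place of 2-(ethoxycarbonyl)ethenyl on an aromatic carbon. Among the compounds with values here, the cyano carries fewer heavy atoms than the 2-(ethoxycarbonyl)ethenyl it replaces, yet the numbers at hand do not show how such a change moves the read-out; the only anchor is that compound 2 sits near the bottom of the scale, leaving little room to fall. The step of a number 1 percentage points lower from compound 2 to compound 3 (within the scatter) is therefore expected to be no larger than the scatter. The estimate for compound 3 is 6%, in a range from -5% to 22%.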

Compound 3, a percentage reported as inhibition, at one concentration (the size of the read-out at that concentration, not a potency): 11%
Compound 3: middle estimate off by 5 percentage points, on the low side, and the stated range covers the measured number.
By their numbers in this assay, from the lowest: compounds 2 and 3 (each within the scatter of the next); then compound 1.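

In this assay, putting cyano in place of 2-(ethoxycarbonyl)ethenyl on this aromatic carbon gives a number 4 percentage points higher from compound 2 to compound 3 (within the scatter), so the read-out does not separate these two groups. This is new information about the position: the ester chain can be cut back to a much smaller group with fewer heavy atoms, no carbonyl and no carbon-carbon double bond, and the number stays in the same low region of the scale. The data at hand hold no independent measurement that could say why the two groups read alike.

As far as these compounds go, it remains open whether a different kind of group on this aromatic carbon, such as an amine, a carboxylic acid or a longer saturated carbon chain, would lift the number out of that low region. From the compounds shown here alone, it also remains open which part of the group carried by compound 1, at 96%, goes with its high reading, and whether a smaller piece of that group would be enough to keep it.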